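Methyl in place of hydrogen on compound 2

The source may report more compounds than this note shows. Statements on the series, on what has been measured and on what is new or still open speak of the compounds shown alone.

Measured in a functional assay on HCT-116 cells (Homo sapiens) for cytotoxicity, read by MTT assay, with a stated time of 48 h; on this read-out lower numbers stand for stronger inhibition and higher numbers for weaker inhibition:
compound 1 (`COc1cc(/C=C/C(=O)C2=C(/C=C/c3ccc(O)c(OC)c3)NC(=O)NC2c2cccc([N+](=O)[O-])c2)ccc1O`) gives 50000 nM
compound 2 (`COc1cc(/C=C/C(=O)C2=C(/C=C/c3ccc(O)c(OC)c3)NC(=S)NC2c2ccccc2)ccc1O`) gives 100000 nM

Compound 2 (100000 nM) sits within the scatter of compound 1, so the two cannot be told apart. Compound 3 (`COc1cc(/C=C/C(=O)C2=C(/C=C/c3ccc(O)c(OC)c3)NC(=S)NC2c2ccc(C)cc2)ccc1O`) comes from compound 2 by methyl in place of hydrogen on an aromatic carbon. Among the compounds with values here, the measured compounds offer no single-place step to gauge this change. No shift beyond the scatter is expected in this assay, and this expectation starts from compound 2 (100000 nM). The expected step (a 1.1-fold lower number from compound 2 to compound 3 (0.05 log units; within the scatter)) has no firm direction. For compound 3 the estimated value is 90000 nM, with an expected range from 35000 nM to 200000 nM.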

Compound 3, half-maximal inhibitory concentration: 50000 nM
For compound 3 the middle estimate is 1.8-fold (0.26 log units) above the measured one, within the range that was stated.
By their numbers in this assay, from the lowest: compounds 1, 3 and 2 (each within the scatter of the next).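

The one single-place step among these compounds reads, in this assay, as a 2.0-fold lower number from compound 2 to compound 3 (0.30 log units; within the scatter). Phenyl to 4-methylphenyl therefore gives no shift that can be told from the scatter, so this place on the aromatic ring, para to a large group, accepts a methyl with no readable effect on the number. No supporting data bear on this step. Going by these compounds, whether an amine, a carboxylic acid or a longer chain at this place would move the number beyond the scatter remains open. On these data alone, a methyl elsewhere on this ring also remains open.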